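The source may report more compounds than this note shows. Statements on the series, on what has been measured and on what is new or still open speak of the compounds shown alone.

Of the compounds shown here, three that share one core have so far been measured in an ADME assay on RAW264.7 cells (Mus musculus) for cytotoxicity, read by MTT assay, with a stated time of 48 h (on this read-out lower numbers stand for higher toxicity in this test and higher numbers for lower toxicity in this test), on mouse cells. Compound 1 (`C#CCN(c1nc(-c2cccc(Br)c2)no1)C1CCCCC1`) gives 31.8 ug/mL in this test, and compound 2 (`C#CCN(c1nc(-c2ccc(F)cc2)no1)C1CCCCC1`) gives 20.9 ug/mL in the same test. Compound 3 (`C#CCN(c1nc(-c2ccc([N+](=O)[O-])cc2)no1)C1CCCCC1`) gives 26.7 ug/mL and lies within the usual scatter of both of the others, so the three numbers cannot be told apart with confidence.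

The next structure is compound 4 (`C#CCN(c1nc(-c2ccc(Br)cc2)no1)C1CCCCC1`), which has bromo in place of nitro on an aromatic carbon, para to a large group. The counted change is bromo in place of nitro on an aromatic carbon and the rest of the molecule stays the same.

Within the data shown here, two measured steps bear on this swap. With 4-fluorophenyl in place of 3-bromophenyl the data show a 1.5-fold lower number from compound 1 to compound 2 (0.18 log units; within the scatter) and with nitro in place of fluoro they show a 1.3-fold higher number from compound 2 to compound 3 (0.11 log units; within the scatter) in the same test. Neither step goes beyond the scatter. Compound 1, which also carries a bromo, gives 31.8 ug/mL and so stays close to the other two. No step beyond the scatter is therefore expected in this assay for this swap. The estimated move is a 1.0-fold lower number from compound 3 to compound 4 (0.01 log units; within the scatter) and it is expected to stay inside the scatter. For compound 4 the estimate is 26 ug/mL with an expected range from 15 ug/mL to 43 ug/mL in this test.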

Compound 4, half-maximal cytotoxic concentration: 15.7 ug/mL
Compound 4: the middle estimate sits 1.7-fold (0.22 log units) above what was measured; measured number inside the range.
By their numbers in this assay, from the lowest: compounds 4, 2, 3 and 1 (each within the scatter of the next, the first and the last beyond it).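

Among these compounds, the clearest new information concerns where the bromo sits rather than which group is present: with 4-bromophenyl in place of 3-bromophenyl, a 2.0-fold lower number from compound 1 to compound 4 (0.31 log units; beyond the scatter) in this assay, the first step in this set to pass the scatter, though only modestly. At the place para to a large group, the change of group does not separate the compounds, with a 1.7-fold lower number from compound 3 to compound 4 (0.23 log units; within the scatter) and a 1.3-fold lower number from compound 2 to compound 4 (0.12 log units; within the scatter), so nitro, fluoro and bromo there cannot be told apart in this test, and compound 4 cannot be called the most toxic of the set even though it has the lowest number. No measurement available here offers a reason for the difference between the two bromo compounds.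

Among the compounds shown here, it remains open whether a fluoro or nitro group would show a similar difference between these two ring positions, or whether this is seen only with bromo. As far as these compounds go, it is also open whether an amine, a carboxylic acid or a methoxy group at the place para to a large group would move the number beyond the scatter, as nitro, fluoro and bromo do not.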